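Swapping a halogen on a thione-bearing core

The source may report more compounds than this note shows. Statements on the series, on what has been measured and on what is new or still open speak of the compounds shown alone.

Measured compounds:
- compound 1 `Fc1cccc(-c2csc(=S)[nH]2)c1`: 28%
- compound 2 `COc1ccc(-c2c[nH]c(=S)s2)cc1`: 0%

In an assay on isolated protein for inhibition of Indoleamine 2,3-dioxygenase 1 (Homo sapiens), read by colorimetric assay, with stated times of 10 min and 30 min, tested at 100 uM (on this read-out higher numbers stand for more inhibition at the one concentration tested (going by the name of the read-out) and lower numbers for less inhibition), compound 1 gives 28%, the higher of the two numbers recorded so far. Compound 2, a differently substituted relative, gives 0%, a gap wide enough to lie beyond the usual scatter of this read-out. Nothing more can be said of that pair, since the two structures differ in more than one place.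

Compound 3 `S=c1[nH]c(-c2cccc(Br)c2)cs1` has not yet been measured. It differs from compound 1 in a single spot: bromo in place of fluoro on an aromatic carbon. Going by the values given here, with no measured pair showing this exact swap, the expectation rests on compound 1 alone, whose value of 28% is the anchor. A change of this kind is expected to move this assay little, so the step of a number 4 percentage points higher from compound 1 to compound 3 (within the scatter) is expected to stay within the scatter. Compound 3 is therefore estimated at 32%, with a range from 10% to 55%.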

Compound 3, a percentage reported as inhibition, at one concentration (the size of the read-out at that concentration, not a potency): 81%
For compound 3 the middle estimate is 49 percentage points below the measured one; measured number outside the range, above it.
By their numbers in this assay, from the lowest: compound 2; then compound 1; then compound 3.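

In this assay, bromo in place of fluoro on an aromatic carbon gives a number 53 percentage points higher from compound 1 to compound 3 (beyond the scatter), and this is the first pair shown that differs in only one place. The result shows that this position, meta to a group of 6 heavy atoms, is highly sensitive to which halogen it carries: exchanging one heavy atom for another is enough for a large step, even though the counts of rings, hydrogen-bond donors, hydrogen-bond acceptors and net charge stay the same. Nothing available explains why this exchange has such a large effect.

The compounds shown leave open how chloro or iodo would behave at this position, and whether a non-halogen group such as an amine or a methyl group could match bromo there. They also leave open whether bromo would give a similar result on another carbon of the same ring.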